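Swapping the Aminophenyl Arm for a Pyrimidine Ring

This account rests on a few compounds, and the source may have more. Where it says the series, first, only, none or still open, it means among the compounds named here.

In an assay (Rattus norvegicus) for inhibition of Fatty-acid amide hydrolase 1 (Homo sapiens) (on this read-out higher numbers stand for weaker inhibition and lower numbers for stronger inhibition), compound 1, `Nc1ccc(-c2cnc(C(=O)CCCCCCc3ccccc3)o2)cc1`, gives 90 nM, the highest of the two numbers shown; its nearest neighbour is compound 2, `O=C(CCCCCCc1ccccc1)c1ncc(-c2cc(C(F)(F)F)ccn2)o1`, at 3.5 nM, a gap beyond the scatter. Compound 3, `O=C(CCCCCCc1ccccc1)c1ncc(-c2ncccc2C(=O)O)o1`, gives only a limit, > 50 nM. The step that the limit leaves unreadable from compound 1 to compound 3 therefore cannot be sized, as the limit of > 50 nM in this assay, at which 1 of the 3 values shown sits, shows. Compound 4, `O=C(CCCCCCc1ccccc1)c1ncc(-c2cncnc2)o1`, differs from compound 1 in one place: pyrimidin-5-yl in place of 4-aminophenyl on an aromatic carbon. Among the compounds with values here, no measured step joins an aminophenyl to a pyrimidinyl ring here, so the only guides are compound 2, where a different nitrogen-containing ring gives a far stronger number, and compound 3, where the 3-carboxypyridin-2-yl ring stays at the limit. Inhibition is expected to strengthen, with the step of a 6.0-fold lower number from compound 1 to compound 4 (0.78 log units; beyond the scatter). Compound 4 is estimated at 15 nM, between 3 nM and 70 nM.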

Compound 4, inhibition constant: 22 nM
Beside the measured number, compound 4's estimate is 1.5-fold (0.17 log units) below it, and the stated range covers the measured number.
By their numbers in this assay, from the lowest: compound 2; then compound 4; then compound 1.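

In this assay, the position next to the ring oxygen does not need the amine's hydrogen-bond donor: pyrimidin-5-yl in place of 4-aminophenyl gives a 4.1-fold lower number from compound 1 to compound 4 (0.61 log units; beyond the scatter). Pyrimidin-5-yl in place of 3-carboxypyridin-2-yl gives an at least 2.2-fold lower number from compound 3 to compound 4 (0.35 log units; beyond the scatter). Compound 3 gives only a limit, so that step is a minimum and its step from compound 1 cannot be read: the limit of > 50 nM in this assay, at which 1 of the 4 values shown sits.

Still open, from the compounds shown here alone, is what the ring nitrogens contribute on their own. A plain phenyl ring or a pyridin-3-yl ring on the same core would separate their contribution from the loss of the amine.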